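Third methoxy on the benzyl group of compound 2

This account rests on a few compounds, and the source may have more. Where it says the series, first, only, none or still open, it means among the compounds named here.

Compound 1 `Nc1cc(N)c2nc(-c3ccccc3)c(NCc3ccc(Cl)c(Cl)c3)nc2c1` gives 1910 nM in a functional assay on SK-MEL-2 cells (Homo sapiens) for inhibition, read by sulforhodamine B assay, with a stated time of 48 h; a higher number here means a weaker inhibitor of growth, a lower number a stronger inhibitor of growth. Compound 2 `COc1ccc(CNc2nc3cc(N)cc(N)c3nc2-c2ccccc2)cc1OC` gives 8710 nM, the second highest of the three numbers in this assay, and compound 3 `CCOC(=O)[C@H](CCC(=O)O)NC(=O)c1ccc(Sc2nc3cc(N)cc(N)c3nc2-c2ccccc2)cc1` gives 19100 nM. Going by the values given here, the single one-place step measured, a 4.6-fold higher number from compound 1 to compound 2 (0.66 log units; beyond the scatter), bears only loosely on compound 4 `COc1cc(CNc2nc3cc(N)cc(N)c3nc2-c2ccccc2)cc(OC)c1OC`, since it swaps the whole substituent pattern, whereas compound 4 differs from compound 2 by methoxy in place of hydrogen on an aromatic carbon. Among the compounds with values here, no measured step adds a single methoxy. Because a 4.6-fold higher number from compound 1 to compound 2 (0.66 log units; beyond the scatter) runs toward a weaker inhibitor, a further methoxy is not expected to strengthen compound 4. For compound 4 a small step is expected, a 1.3-fold higher number from compound 2 to compound 4 (0.10 log units; within the scatter), toward a weaker inhibitor. The estimate for compound 4 is 11000 nM, with a range of 4000 nM to 30000 nM.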

Compound 4, concentration for 50% growth inhibition: 16200 nM
Compound 4: middle estimate off by 1.5-fold (0.17 log units), on the low side; low and high end bracket the measured number.
By their numbers in this assay, from the lowest: compound 1; then compounds 2, 4 and 3 (each within the scatter of the next, the first and the last beyond it).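

In this assay, methoxy in place of hydrogen on an aromatic carbon, ortho to a methoxy group, gives a 1.9-fold higher number from compound 2 to compound 4 (0.27 log units; within the scatter) and so falls within the usual scatter. Going by these compounds alone, this is the first single-group step on the benzyl ring with the rest of the substituent pattern held fixed, and at this position the third methoxy leaves compound 2 and compound 4 indistinguishable. No measured evidence bears on this result.

On these data alone, whether hydroxy, an amine or a longer chain such as ethoxy would be accommodated equally at this position remains open. The same holds for a carboxylic acid on this ring.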